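Replacing a Pyridine with Methyl: What Cytotoxicity to Expect

This account rests on a few compounds, and the source may have more. Where it says the series, first, only, none or still open, it means among the compounds named here.

Compound 1, `Cn1ccnc1Sc1cnc(-c2ccc(Cl)cc2)nc1-c1ccccc1O`, gives 80100 ug/mL in an ADME assay on MDCK cells (Canis lupus familiaris) for cytotoxicity; on this read-out lower numbers stand for higher toxicity in this test and higher numbers for lower toxicity in this test.
Compound 2, `Cn1ccnc1Sc1cnc(-c2ccncc2)nc1-c1ccccc1O`, gives 64700 ug/mL in this assay.

Compound 2 holds the lower of these two numbers, with compound 1 nearest; the step of a 1.2-fold lower number from compound 1 to compound 2 (0.09 log units; within the scatter) stays within the scatter. Compound 3, `Cc1ncc(Sc2nccn2C)c(-c2ccccc2O)n1`, differs from compound 2 by methyl in place of pyridin-4-yl on an aromatic carbon. For the measured compounds named here, the only measured step touches the same position and moved nothing beyond the scatter, so in this assay compound 3 is expected to show no step beyond the scatter, and an estimate of 60000 ug/mL with a range from 30000 ug/mL to 120000 ug/mL is expected, amounting to a 1.1-fold lower number from compound 2 to compound 3 (0.03 log units; within the scatter).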

Compound 3, half-maximal cytotoxic concentration: 577000 ug/mL
Beside the measured number, compound 3's estimate is 9.6-fold (0.98 log units) below it; the whole stated range lies below it.
By their numbers in this assay, from the lowest: compounds 2 and 1 (each within the scatter of the next); then compound 3.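

In this assay, this position turns out to matter after all: pyridin-4-yl and 4-chlorophenyl gave numbers within the scatter of each other, yet methyl gives an 8.9-fold higher number from compound 2 to compound 3 (0.95 log units; beyond the scatter) and a 7.2-fold higher number from compound 1 to compound 3 (0.86 log units; beyond the scatter) with both steps beyond the scatter. The two compounds carrying a ring here sit together, and the methyl compound stands apart on the side of lower toxicity in this test. Nothing available explains this gap. Still open, as far as these compounds go, is whether the rise goes with methyl itself or simply with having no ring at this place. An ethyl group, a longer chain or an amine here could separate those two readings.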